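This account rests on a few compounds, and the source may have more. Where it says the series, first, only, none or still open, it means among the compounds named here.

Compound 1 `C=CC1=C(C(=O)NC(C)(C)C)C(c2ccc(OC)cc2)OC1` — in a functional assay on QGY7701 cells (Homo sapiens) for cytotoxicity, read by MTT assay, with a stated time of 24 h (on this read-out lower numbers stand for stronger inhibition and higher numbers for weaker inhibition), compound 1 gives > 100000 nM, which is a limit of the assay and not a number.
Compound 2 `C=CC1=C(C(=O)NCCCCC)C(c2ccc(F)cc2)OC1` — in this assay compound 2 gives > 100000 nM, also a limit.
Compound 3 `C=CC1=C(C(=O)NCC(C)C)C(c2ccc(F)cc2)OC1` — in this assay compound 3 gives > 100000 nM, again a limit.

All three measured compounds thus sit at the same place: the limit of > 100000 nM in this assay, at which 3 of the 3 values shown sit. Compound 1 stands there too, so only a limit is known for it, and no order among the three can be read.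

Compound 4 `C=CC1=C(C(=O)NCCC)C(c2ccc(OC)cc2)OC1` differs from compound 1 in one place: propyl in place of tert-butyl on an amide-type nitrogen. Going by the values given here, the only measured step that resembles it, a change of the chain on the amide nitrogen, is a step that the two limits leave unreadable from compound 2 to compound 3, which the two limits leave unreadable in size. Among the compounds with values here, no measured step therefore tells how much, or in which direction, such a change moves the read-out in this assay. Since every compound shown remains at the limit, compound 4 is expected to remain there as well, with the step that the limit leaves unreadable from compound 1 to compound 4 estimated as none beyond the scatter.

Compound 4 is estimated at 200000 nM, within 100000 nM to 1000000 nM.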

Compound 4, half-maximal inhibitory concentration: > 100000 nM
Compound 4: no number, only a limit; the forecaster's own chance of this, stated with the estimate: 85%; the middle value is on the limit's open side.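

Compound 1 and compound 4 each give only a limit, so no step between them can be read: the limit of > 100000 nM in this assay, at which 4 of the 4 values shown sit.

The compounds shown leave open where any of the four truly lies beyond that limit, and whether the chain on the amide nitrogen matters in this assay.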